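The compounds below may be only part of what the source reports. "The series", "measured", "known", "first", "only" and "open" are said of these compounds alone.

Compound 1, `COc1cc(CNC(=S)NC(CCc2ccc(C(C)(C)C)cc2)COC(=O)C(C)(C)C)ccc1O`, gives 36.5 nM in an assay on CHO cells for displacement of a labelled ligand from transient receptor potential cation channel subfamily V member 1 (Rattus norvegicus); on this read-out lower numbers stand for stronger inhibition and higher numbers for weaker inhibition. Compound 2, `COc1cc(CNC(=S)NCC(COC(=O)C(C)(C)C)Cc2ccc(C)c(C)c2)c(I)cc1O`, gives 18.9 nM.

Of the two measured compounds, compound 1 gives the highest number; its nearest neighbour is compound 2, whose value lies within the scatter of repeated measurements, so the two cannot be told apart here. Compound 3, `COc1cc(CNC(=S)NC(CCc2ccc(C(C)(C)C)cc2)COC(=O)C(C)(C)C)cc(Cl)c1O`, differs from compound 1 by chloro in place of hydrogen on an aromatic carbon, in words chloro in place of hydrogen on an aromatic carbon. Within the data shown here, no measured pair shows this change, so the step is uncertain; a modest move toward lower numbers, hardly beyond the scatter, is expected. Compound 3 is expected to give about 20 nM, between 7 nM and 60 nM, a step of a 1.8-fold lower number from compound 1 to compound 3 (0.26 log units; within the scatter).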

Compound 3, inhibition constant: 122 nM
The estimate for compound 3 lay 6.1-fold (0.79 log units) below the measured number; the whole stated range lies below it.
By their numbers in this assay, from the lowest: compounds 2 and 1 (each within the scatter of the next); then compound 3.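

Chloro in place of hydrogen, on the aromatic carbon ortho to the hydroxy group and meta to the methoxy group, is the first single change that can be read in this assay: it gives a 3.3-fold higher number from compound 1 to compound 3 (0.52 log units; beyond the scatter), so on the core of compound 1 this position does not take chloro without weaker inhibition. This rests on one pair of compounds. Nothing shown explains the step.

From the compounds shown here alone, whether fluoro, bromo or a methyl group at this carbon would give a similar step remains open. So does whether chloro here would act alike on the core of compound 2.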